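This account rests on a few compounds, and the source may have more. Where it says the series, first, only, none or still open, it means among the compounds named here.

In an assay on isolated protein for binding affinity to secreted frizzled-related protein 1 (Homo sapiens), read by fluorescence (a higher number here means a weaker inhibitor, a lower number a stronger inhibitor), the two measured compounds read as follows: compound 1 `CN(C)CC(=O)N1CCC(NS(=O)(=O)c2cc(S(=O)(=O)c3ccccc3)ccc2C(F)(F)F)CC1` gives 300 nM; compound 2 `CC(C)(C)OC(=O)N1CCC[C@H]1C(=O)N1CCC(NS(=O)(=O)c2cc(S(=O)(=O)c3ccccc3)ccc2C(F)(F)F)CC1` gives 60 nM.

For the measured compounds named here, compound 2 holds the lower of the two numbers, and the only measured step, a 5.0-fold lower number from compound 1 to compound 2 (0.70 log units; beyond the scatter), separates it from compound 1. Compound 3 `O=C([C@@H]1CCCN1C(=O)c1ccncc1)N1CCC(NS(=O)(=O)c2cc(S(=O)(=O)c3ccccc3)ccc2C(F)(F)F)CC1` differs from compound 2 by pyridin-4-yl in place of tert-butoxy on a carbonyl carbon. Going by the values given here, the one known step concerns a change at the other end of the same amide and so bears only loosely on this one; no measured pair exchanges a tert-butoxy for an aryl group at this position. Among the compounds with values here, with only that indirect guide, a step of moderate size in this assay is the most that can be supported, and its direction is open. Compound 3 is therefore expected to sit near compound 2, estimated at 80 nM (range 25 nM to 300 nM), which would mean a step of a 1.3-fold higher number from compound 2 to compound 3 (0.12 log units; within the scatter).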

Compound 3, half-maximal inhibitory concentration: 70 nM
Beside the measured number, compound 3's estimate is 1.1-fold (0.06 log units) above it; measured number inside the range.
By their numbers in this assay, from the lowest: compounds 2 and 3 (each within the scatter of the next); then compound 1.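

In this assay, pyridin-4-yl and tert-butoxy on a carbonyl carbon whose other neighbour is an amide-type nitrogen in a ring cannot be told apart, with a 1.2-fold higher number from compound 2 to compound 3 (0.07 log units; within the scatter). The earlier compounds shown here showed only that this end of the molecule could respond to a change, whereas this pair shows that a six-membered aromatic ring with one hetero atom and a ringless tert-butoxy can occupy this place with no difference beyond the scatter. Nothing available bears on the reason for this result.

Going by these compounds, it remains open whether phenyl or pyridin-3-yl would read the same way, which would show whether the ring nitrogen or its placement matters. A small methyl group, or a chain ending in a primary amine or a carboxylic acid, would test how widely this equivalence extends.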